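The source may hold more compounds than are shown below. What is called first, only, known or untested is meant among the compounds shown, and "the series" means these compounds.

Measured in a functional assay on EKVX cells (Homo sapiens) for antiproliferative activity, with a stated time of 48 h; on this read-out lower numbers stand for higher toxicity in this test and higher numbers for lower toxicity in this test:
compound 1 `Cc1cc(O)c(C2=NN(c3ccc(S(N)(=O)=O)cc3)C(c3ccccc3O)C2)cc1Cl` gives 39700 nM
compound 3 `Cc1cc(O)c(C2=NN(c3ccc(S(N)(=O)=O)cc3)C(/C=C/c3ccccc3)C2)cc1Cl` gives 87400 nM
compound 2 `Cc1cc(O)c(C2=NN(c3ccc(S(N)(=O)=O)cc3)C(c3ccccc3Cl)C2)cc1Cl` reaches only a limit of this assay, > 100000 nM

Among the two numbers that are not limits, compound 3 stands highest; its nearest neighbour is compound 1, separated by a 2.2-fold higher number from compound 1 to compound 3 (0.34 log units; beyond the scatter). The value of compound 2 is a limit, (the limit of > 100000 nM in this assay, at which 1 of the 3 values shown sits), and not a number.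

Compound 4 `COc1ccc(C2CC(c3cc(Cl)c(C)cc3O)=NN2c2ccc(S(N)(=O)=O)cc2)c(OC)c1OC` has not yet been measured. It differs from compound 3 at one place: 2,3,4-trimethoxyphenyl in place of 2-phenylethenyl on a saturated ring carbon. Two measured steps change the group at this same saturated ring carbon. The step of a 2.2-fold higher number from compound 1 to compound 3 (0.34 log units; beyond the scatter) was modest, and the step of an at least 1.1-fold lower number from compound 2 to compound 3 (0.05 log units; that floor lies within the scatter) lies within the scatter. Swapping the group at this carbon has so far moved this assay only modestly or not at all, so a step of at most modest size is expected here, with no firm direction. Compound 4 is therefore estimated at 70000 nM, with a range from 30000 nM to 160000 nM. The expected step of a 1.2-fold lower number from compound 3 to compound 4 (0.10 log units; within the scatter) is small, and a limit rather than a number remains possible.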

Compound 4, concentration lethal to 50% of the cells: > 100000 nM
Compound 4 was reported as a limit; the forecaster's own chance of this, stated with the estimate: 30%; at least 1.4-fold (0.15 log units) between middle value and limit.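

In this assay, compound 4 gives a limit and not a number, which makes any step between it and compound 2 unreadable: the limit of > 100000 nM in this assay, at which 2 of the 4 values shown sit.

Set against the other two compounds, the 2,3,4-trimethoxyphenyl group gives an at least 1.1-fold higher number from compound 3 to compound 4 (0.05 log units; that floor lies within the scatter), and that step does not separate the pair, but it also gives an at least 2.5-fold higher number from compound 1 to compound 4 (0.40 log units; beyond the scatter). Compound 1, with its 2-hydroxyphenyl group, now has the lowest number of the four, meaning the highest toxicity in this test, and its steps to all three others lie beyond the scatter. Oxygen on this aromatic ring is therefore not enough on its own to match compound 1, since the three methoxy groups of compound 4 do not do so.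

Still open, going by these compounds, is whether a 2-methoxyphenyl or a 2-aminophenyl group at this carbon would keep the lower number of compound 1. On these data alone, the true values of compound 2 and compound 4 also remain unknown.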